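The compounds below may be only part of what the source reports. "The series", "measured", "known", "first", "only" and "open" are said of these compounds alone.

Compound 1 `Cc1cc(/C=C/C#N)cc(C)c1Oc1cc(Nc2ccc(C#N)cc2)nc(NC2CC2)c1` gives 24800 nM
Compound 2 `Cc1cc(/C=C/C#N)cc(C)c1Oc1cc(NC2CC2)nc(Nc2ccc(C#N)cc2)n1` gives 3000 nM
Compound 3 `Cc1cc(/C=C/C#N)cc(C)c1Oc1cc(NCCC#N)nc(Nc2ccc(C#N)cc2)n1` gives 1000 nM

In an ADME assay on MT4 cells (Homo sapiens) for cytotoxicity, read by MTT assay, with a stated time of 5 days (on this read-out lower numbers stand for higher toxicity in this test and higher numbers for lower toxicity in this test), compound 1 holds the highest of the three numbers, and compound 2 and compound 3 both lie lower by more than the scatter. Compound 4 `Cc1cc(/C=C/C#N)cc(C)c1Oc1cc(Cl)nc(Nc2ccc(C#N)cc2)c1` carries chloro in place of cyclopropylamino on an aromatic carbon, next to the ring nitrogen: chloro in place of cyclopropylamino on an aromatic carbon. Within the data shown here, no measured pair shows this exchange. The nearest evidence is the modest 3.0-fold lower number from compound 2 to compound 3 (0.48 log units; beyond the scatter), which changes a group on the nitrogen but keeps that nitrogen, so it bears only loosely. Compound 1 also sits at the top of the range, with compound 3 at 1000 nM far lower, so a move towards a lower number in this assay seems more likely than a rise, though a result near compound 1 remains possible. The expected change is a 2.5-fold lower number from compound 1 to compound 4 (0.39 log units; beyond the scatter), of similar size to the measured step. For compound 4 the estimated value is 10000 nM, with an expected range from 3000 nM to 30000 nM.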

Compound 4, half-maximal cytotoxic concentration: > 311000 nM
Compound 4: no number, only a limit; the forecaster's own chance of this, stated with the estimate: 10%; middle value at least 31-fold (1.49 log units) from the limit.
By their numbers in this assay, from the lowest: compound 3; then compound 2; then compound 1. At a limit, above all of these: compound 4.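

In this assay, chloro in place of cyclopropylamino on the aromatic carbon next to the ring nitrogen gives an at least 12-fold higher number from compound 1 to compound 4 (1.09 log units; beyond the scatter), so this position can move the read-out strongly towards lower toxicity in this test. Among these compounds, the only earlier step, a 3.0-fold lower number from compound 2 to compound 3 (0.48 log units; beyond the scatter), exchanged a group on a nitrogen and kept that nitrogen, whereas this exchange removes the whole cyclopropylamino group and the number goes up, not down. The reading for compound 4 is a limit and not a number: the limit of > 311000 nM in this assay, at which 1 of the 4 values shown sits.

The compounds shown leave open whether a methyl group, a methoxy group or a plain amino group at this place would give a number as high, and so whether the rise follows chloro itself or the departure of cyclopropylamino. On these data alone, the full size of the step also stays open.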